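Dropping the Chloro: From Compound 1 to Compound 3

The source may report more compounds than this note shows. Statements on the series, on what has been measured and on what is new or still open speak of the compounds shown alone.

Within the data shown here, compound 1 `Cc1c(OCCCCOc2ccc(C(=O)O)cc2Cl)ccc(C(=O)CC2CCCC2)c1O` gives the higher of the two values measured so far in an assay on HEK293 cells for positive allosteric modulation of metabotropic glutamate receptor 2 (Rattus norvegicus), read by thallium flux, with a stated time of 2.5 min (a higher number here means a larger maximal response, a lower number a smaller maximal response), at 82.2%. Compound 2 `Cc1c(OCCCCOc2cccc(C(=O)O)c2)ccc(C(=O)CC(C)C)c1C`, which differs from it in several places, gives 12.1% in this assay, a gap beyond the usual scatter. Compound 3 `Cc1c(OCCCCOc2ccc(C(=O)O)cc2)ccc(C(=O)CC2CCCC2)c1O` has not yet been measured in this assay. It differs from compound 1 by one change: hydrogen in place of chloro on an aromatic carbon. Among the measured compounds shown here, no measured pair isolates this change, so the direction rests on expectation alone. Compound 3 is expected to show a moderate loss of maximal response, an estimated step of a number 22.2 percentage points lower from compound 1 to compound 3 (beyond the scatter). In this assay compound 3 is estimated at 60%, between 25% and 90%.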

Compound 3, largest response reached (reported as percent of maximum), in percent of the reference or control that the assay uses: 82.6%
The estimate for compound 3 lay 22.6 percentage points below the measured number, within the range that was stated.
By their numbers in this assay, from the lowest: compound 2; then compounds 1 and 3 (each within the scatter of the next).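

In this assay, among these compounds, this pair isolates the chloro for the first time: hydrogen in its place on the aromatic carbon ortho to a large group and meta to a carboxy group gives a number 0.4 percentage points higher from compound 1 to compound 3 (within the scatter) and leaves the maximal response within the scatter. The chloro is therefore not needed for the maximal response in this pair, and 4-carboxyphenyl serves as well as 4-carboxy-2-chlorophenyl.

As far as these compounds go, whether a fluoro or a methoxy group at this place would also keep the response remains open. Nothing at hand explains why the response holds.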